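Biaryl amide TRPV1 antagonists: sulfonimide in place of propoxy

The source may hold more compounds than are shown below. What is called first, only, known or untested is meant among the compounds shown, and "the series" means these compounds.

Measured compounds:
- compound 1, `C[C@@H]1CN(c2ncccc2C(F)(F)F)CCN1C(=O)Nc1ccc(C(F)(F)F)cc1`: 17 nM
- compound 2, `Cc1cccnc1-c1ccc(C(=O)Nc2ccc(F)cc2)cc1`: limit, > 4000 nM
- compound 3, `CCCOc1cccnc1-c1ccc(C(=O)Nc2ccc(C(C)(C)C)cc2)cc1`: 62 nM

In a functional assay for antagonist activity at transient receptor potential cation channel subfamily V member 1 (Homo sapiens), read by FLIPR (on this read-out higher numbers stand for weaker inhibition and lower numbers for stronger inhibition), compound 1 gives 17 nM. Compound 2 reaches only (the limit of > 4000 nM in this assay, at which 1 of the 3 values shown sits), a limit of the assay and not a number. In this assay compound 3 gives 62 nM; of the two numbers on hand this is the higher one, and the gap to compound 1 lies beyond the usual scatter. No pair of these compounds differs in a single place, so no measured step is available; compounds 1 and 3 share only the trifluoromethyl-bearing or tert-butyl-bearing anilide end and differ in their cores.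

Compound 4, `CC(C)(C)c1ccc(NC(=O)c2ccc(-c3ncccc3N(S(C)(=O)=O)S(C)(=O)=O)cc2)cc1`, has yet to be measured. It differs from compound 3 by bis(methylsulfonyl)amino in place of propoxy on an aromatic carbon. With no measured step of this kind in the set, the direction must be guessed: a much bulkier, more acceptor-rich group replaces the propoxy at the same aromatic carbon, and the expectation here is a loss of inhibition, beyond the scatter, with a real chance that only a limit is returned. Compound 4 is estimated at 600 nM, within 120 nM to 4000 nM, which would be an expected step of a 9.7-fold higher number from compound 3 to compound 4 (0.99 log units; beyond the scatter) in this assay.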

Compound 4, half-maximal inhibitory concentration: 0.8 nM
The estimate for compound 4 lay 750-fold (2.88 log units) above the measured number; measured number below the stated range.
By their numbers in this assay, from the lowest: compound 4; then compound 1; then compound 3. At a limit, above all of these: compound 2.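

In this assay, the position on an aromatic carbon of the six-membered aromatic ring with 1 nitrogen, ortho to a large group and two atoms from the ring nitrogen, proves highly sensitive to the substituent it carries: replacing propoxy with bis(methylsulfonyl)amino gives a 78-fold lower number from compound 3 to compound 4 (1.89 log units; beyond the scatter). The change therefore does not merely preserve inhibition, as a group of 9 heavy atoms with 4 hydrogen-bond acceptors replaces one of 4 heavy atoms with 1 hydrogen-bond acceptor, and inhibition becomes stronger. Before this pair, the compounds shown offered no measured step at this position, so larger groups here could not be judged at all. Nothing measured among these compounds bears on the reason for the step.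

Still open, going by these compounds, is whether both methylsulfonyl groups are needed, which a single methylsulfonylamino group at the same carbon would test, and how a methoxy or a longer alkoxy chain would compare with propoxy. On these data alone, the step also rests on one pair carrying the tert-butyl anilide, so its size with a trifluoromethyl anilide or another amide end remains unknown.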